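A few compounds are considered here, and "the series" means these few. Any claim that something is new, unique, unknown or untested is made for them only; others in the source may bear on it.

Compound 2 `COc1cc(C(=O)N2CCN(C(=O)c3cc(OC)c(OC)c(OC)c3)C(COC(=O)NC(C)C(C)(C)C)C2)cc(OC)c1OC` carries a carbamate on the shared core, and in a functional assay (Oryctolagus cuniculus) for inhibition of platelet-activating factor receptor (Cavia porcellus) (a higher number here means a weaker inhibitor, a lower number a stronger inhibitor), compound 2 gives 170 nM. Its ester counterpart, compound 1 `CCCCCCCC(=O)OCC1CN(C(=O)c2cc(OC)c(OC)c(OC)c2)CCN1C(=O)c1cc(OC)c(OC)c(OC)c1`, gives 310 nM in this assay; the step of a 1.8-fold lower number from compound 1 to compound 2 (0.26 log units; within the scatter) leaves the two within the scatter of each other, so neither can be ranked above the other. Compound 3 `CCC(C)(C)NC(=O)OCC1CN(C(=O)c2cc(OC)c(OC)c(OC)c2)CCN1C(=O)c1cc(OC)c(OC)c(OC)c1` differs from compound 2 by 1,1-dimethylpropyl in place of 1,2,2-trimethylpropyl on an amide-type nitrogen. Going by the values given here, the only measured step replaced an entire group on a carbonyl carbon without moving beyond the scatter, and the change to compound 3 is confined to the alkyl on the amide-type nitrogen. Compound 3 is therefore expected to come out at 170 nM (range 70 nM to 400 nM), a step of no change at the digits printed from compound 2 to compound 3 (within the scatter) that is expected to stay within the scatter.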

Compound 3, half-maximal inhibitory concentration: 320 nM
Beside the measured number, compound 3's estimate is 1.9-fold (0.27 log units) below it; the range from low to high includes it.
By their numbers in this assay, from the lowest: compounds 2, 1 and 3 (each within the scatter of the next).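

In this assay the exchange confined to the alkyl on the amide-type nitrogen gives a 1.9-fold higher number from compound 2 to compound 3 (0.27 log units; within the scatter) and so does not separate 1,1-dimethylpropyl from 1,2,2-trimethylpropyl. The wider exchange on a carbonyl carbon gives a 1.0-fold higher number from compound 1 to compound 3 (0.01 log units; within the scatter) and does not separate (1,1-dimethylpropyl)amino from heptyl either. Nothing available explains these readings. The compounds shown leave open whether a phenyl ring, a cyclohexyl ring or a simple methyl on this nitrogen would also stay within the scatter. They also leave open whether an alkyl chain carrying a carboxylic acid or an amine would do so.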